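Swapping hydroxy for amino on a potent sulfonamide

The source may report more compounds than this note shows. Statements on the series, on what has been measured and on what is new or still open speak of the compounds shown alone.

Measured in a functional assay on RF1 cells (Homo sapiens) for cytotoxicity, read by trypan blue exclusion, with a stated time of 96 h; on this read-out lower numbers stand for stronger inhibition of growth and higher numbers for weaker inhibition of growth:
- Compound 1 `COc1ccc(NS(=O)(=O)/C=C/c2c(OC)cc(OC)cc2OC)cc1`: 50 nM
- Compound 2 `COc1cc(OC)c(/C=C/S(=O)(=O)Nc2ccc(OC)c(O)c2)c(OC)c1`: 10 nM

Of these two compounds, compound 2 has the lower number at 10 nM, so it inhibits growth more strongly, while compound 1 stands higher at 50 nM. Compound 3 `COc1cc(OC)c(/C=C/S(=O)(=O)Nc2ccc(OC)c(N)c2)c(OC)c1` has not yet been measured. It differs from compound 2 in one place: amino in place of hydroxy on an aromatic carbon. Put simply, this is amino in place of hydroxy on an aromatic carbon, ortho to a methoxy group.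

For the measured compounds named here, only one measured step bears on this change: a 5.0-fold lower number from compound 1 to compound 2 (0.70 log units; beyond the scatter). It came from putting hydroxy in place of hydrogen, and it was modest. Going by the values given here, it shows that a change at this spot can shift the number, but no measured compound carries amino, so the data cannot show how amino compares with hydroxy. A step smaller than that modest one is therefore expected in this assay, with the number slightly higher if it moves at all. The expected change is a 1.5-fold higher number from compound 2 to compound 3 (0.18 log units; within the scatter). For compound 3 the estimated value is 15 nM, with an expected range of 4 nM to 60 nM.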

Compound 3, concentration for 50% growth inhibition: 4 nM
The estimate for compound 3 lay 3.8-fold (0.57 log units) above the measured number; the measured number falls inside the stated range.
By their numbers in this assay, from the lowest: compound 3; then compound 2; then compound 1.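

In this assay, amino and hydroxy are not interchangeable on this aromatic carbon, ortho to a methoxy group: the swap gives a 2.5-fold lower number from compound 2 to compound 3 (0.40 log units; beyond the scatter). Hydroxy was previously the only group measured here, so the earlier compounds could not show whether another group could match it; amino goes further, with a 13-fold lower number from compound 1 to compound 3 (1.10 log units; beyond the scatter), so the improvement over hydrogen is not unique to hydroxy. The two groups have the same printed counts of hydrogen-bond donors and acceptors, and neither carries a net charge, so those counts do not separate them, and nothing measured here accounts for the difference.

The compounds shown leave open how a methylamino group or an acetamide, or a carboxylic acid on the same carbon, would compare with amino. They also leave open whether amino would keep its lower number against hydroxy if the neighbouring methoxy group were replaced by an ethoxy group or a hydrogen.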